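The source may report more compounds than this note shows. Statements on the series, on what has been measured and on what is new or still open speak of the compounds shown alone.

Measured in a functional assay on M21 cells (Homo sapiens) for antiproliferative activity, read by sulforhodamine B assay, with a stated time of 48 h; a lower number here means a stronger inhibitor, a higher number a weaker inhibitor:
- compound 1 `CCCN1CCN(c2ccc(S(=O)(=O)Oc3ccccc3OC)cc2)C1=O`: > 100000 nM
- compound 2 `CCCN1CCN(c2ccc(S(=O)(=O)Oc3cccc([N+](=O)[O-])c3)cc2)C1=O`: 38000 nM

The entry for compound 1 is a limit of the assay, not a number. Among the compounds with values here, compound 2 therefore holds the only true number, 38000 nM. Compound 3 `CCCN1CCN(c2ccc(S(=O)(=O)Oc3ccc(F)cc3)cc2)C1=O` has 4-fluorophenyl in place of 3-nitrophenyl on an oxygen. Within the data shown here, only one measured step bears on this place, an at least 2.6-fold lower number from compound 1 to compound 2 (0.42 log units; beyond the scatter), and it rests on (the limit of > 100000 nM in this assay, at which 1 of the 2 values shown sits). That step lies beyond the scatter but does not show how a 4-fluorophenyl group will behave. In this assay, only a small move toward a higher number is expected, with the estimated change a 1.3-fold higher number from compound 2 to compound 3 (0.12 log units; within the scatter) staying within the scatter. Compound 3 is estimated at 50000 nM, with an expected range of 18000 nM to 100000 nM.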

Compound 3, half-maximal inhibitory concentration: 14000 nM
Compound 3: the middle estimate sits 3.6-fold (0.55 log units) above what was measured; measured number below the stated range.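

In this assay, the group on the oxygen whose other neighbour is the sulfonyl sulfur now separates two true numbers: 4-fluorophenyl in place of 3-nitrophenyl gives a 2.7-fold lower number from compound 2 to compound 3 (0.43 log units; beyond the scatter). The wider step reads an at least 7.1-fold lower number from compound 1 to compound 3 (0.85 log units; beyond the scatter). Compound 1 remains a limit, not a number: the limit of > 100000 nM in this assay, at which 1 of the 3 values shown sits.

As far as these compounds go, how a 4-chlorophenyl, 4-aminophenyl or 4-carboxyphenyl group would read at this place stays open. The compounds shown also leave open any change elsewhere on the shared core, so nothing here extends beyond this one place.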